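Swapping chloro for fluoro on a thiosemicarbazone drawn without geometry

A few compounds are considered here, and "the series" means these few. Any claim that something is new, unique, unknown or untested is made for them only; others in the source may bear on it.

The series consists of four thiosemicarbazones sharing one core. Compound 1 `C/C(=N\NC(=S)Nc1ccc(Cl)cc1)c1ccccn1` carries a chloro group and is drawn with a defined double-bond geometry; compound 3 `CC(=NNC(=S)Nc1ccc(Cl)cc1)c1ccccn1` has the same atoms and bonds but is drawn without that configuration, the two differing only in the two compounds have the same atoms and bonds; at least one stereo element is drawn with a configuration in one of them and without one in the other: 1 of 1 stereo elements differ; a double bond is drawn E in compound 1 and without a configuration in compound 3. Compound 2 `C/C(=N\NC(=S)Nc1ccc(F)cc1)c1ccccn1` is the fluoro counterpart of compound 1, and compound 4 `CC(=NNC(=S)Nc1ccc(F)cc1)c1ccccn1`, not yet measured, is the fluoro counterpart of compound 3.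

In a functional assay on T98G cells (Homo sapiens) for cytotoxicity, read by MTT assay, with a stated time of 48 h (a lower number here means a stronger inhibitor, a higher number a weaker inhibitor), compound 1 gives 5.9 nM. In this assay compound 3 gives 5.9 nM, and the pair shows no change at the digits printed from compound 1 to compound 3 (within the scatter); the only thing separating them is the fact that one of compounds 1 and 3 is drawn with a defined configuration and the other without, at the place where they differ. Compound 2 gives 17 nM in this assay, so the change fluoro in place of chloro on an aromatic carbon produced a 2.9-fold higher number from compound 1 to compound 2 (0.46 log units; beyond the scatter).

The same change is now made from compound 3 to compound 4, namely (fluoro in place of chloro on an aromatic carbon). It is the same change at the same place. Since compound 3 sits level with compound 1, the step is expected to follow the one already measured. The step from compound 3 to compound 4 is expected to be a 2.9-fold higher number from compound 3 to compound 4 (0.46 log units; beyond the scatter). That expectation rests on compound 1 and compound 2, whose step was a 2.9-fold higher number from compound 1 to compound 2 (0.46 log units; beyond the scatter). Compound 4 is therefore estimated at 17 nM in this assay, with a likely range from 8 nM to 36 nM.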

Compound 4, half-maximal inhibitory concentration: 17 nM
For compound 4 middle estimate and measured number coincide at the digits printed, and the stated range covers the measured number.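

In this assay, putting fluoro in place of chloro on the aromatic carbon gives a 2.9-fold higher number from compound 3 to compound 4 (0.46 log units; beyond the scatter), and this agrees with the step already seen on the other drawing of the core: the same change on two cores in this assay, a 2.9-fold higher number (0.46 log units; beyond the scatter) from compound 1 to compound 2 and a 2.9-fold higher number (0.46 log units; beyond the scatter) from compound 3 to compound 4, 1.0-fold (0.00 log units) apart, within the scatter of two such steps. The drawn configuration leaves the fluoro pair as it left the chloro pair, with no change at the digits printed from compound 2 to compound 4 (within the scatter), so the two compounds that differ only in how the double bond is drawn read alike here: the fact that one of compounds 2 and 4 is drawn with a defined configuration and the other without, at the place where they differ. This shows that the swap repeats in size across the two forms shown, but those forms have the same atoms and bonds, so the repeat amounts to one change on a single skeleton, seen twice in one cell assay, and it does not show that the step would carry over to a core with different atoms or to any other assay.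

The compounds shown hold only chloro and fluoro at this place, so how a bromo, methyl or methoxy group there would read in this assay remains open. Also open, going by these compounds, is whether the same swap would give a step of this size on a core with a carbonyl in place of the thiocarbonyl, or with a longer chain in place of the methyl on the double bond.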